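This account rests on a few compounds, and the source may have more. Where it says the series, first, only, none or still open, it means among the compounds named here.

Compound 3, `C#CCn1cc(C(=O)NC(CC(=O)Nc2ccccc2)c2ccccc2)c(=O)c2ccc(Cl)nc21`, is the parent for this step. In a functional assay on DU-145 cells (Homo sapiens) for cytotoxicity, read by MTT assay, with a stated time of 72 h (a higher number here means a weaker inhibitor, a lower number a stronger inhibitor), compound 3 gives only a limit, > 10000 nM, which is the point noted in the limit of > 10000 nM in this assay, at which 1 of the 3 values shown sits. Its two measured neighbours are compound 1, `C#CCn1cc(C(=O)NC(CC(=O)Nc2ccccc2)c2ccccc2)c(=O)c2cc(F)c(Cl)nc21`, which in this assay gives 5900 nM, and compound 2, `C#CCn1cc(C(=O)NC(CC(=O)Nc2ccccn2)c2ccccc2)c(=O)c2ccc(Cl)nc21`, which in this assay gives 4900 nM. The two steps to compound 3 read an at least 1.6-fold higher number from compound 1 to compound 3 (0.22 log units; that floor lies within the scatter) and an at least 2.0-fold higher number from compound 2 to compound 3 (0.30 log units; that floor lies within the scatter); both are floors only, and neither floor clears the scatter.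

Compound 4 is `C#CCn1cc(C(=O)NC(CC(=O)NC2CCCC2)c2ccccc2)c(=O)c2ccc(Cl)nc21`. The change from compound 3 is cyclopentyl in place of phenyl on an amide-type nitrogen. Within the data shown here, of the measured steps, only the one from compound 2 to compound 3 touches the same amide-type nitrogen, and it swaps one aromatic group for another, so no measured step covers an aromatic to saturated exchange here. With compound 3 sitting at a limit, the expectation for compound 4 is a number near that limit, a step that the limit leaves unreadable from compound 3 to compound 4, with no direction settled beyond the scatter. The estimate for compound 4 in this assay is 12000 nM, within 5000 nM to 30000 nM.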

Compound 4, half-maximal inhibitory concentration: > 10000 nM
Compound 4: a limit, no number; the forecaster's own chance of this, stated with the estimate: 55%; the middle value is on the limit's open side.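

In this assay compound 4 gives > 10000 nM, which is a limit and not a number, and the steps between limits cannot be read, so the change from phenyl to cyclopentyl on the amide-type nitrogen has no readable size. Among these compounds, the one readable step is an at least 2.0-fold higher number from compound 2 to compound 4 (0.30 log units; that floor lies within the scatter), so cyclopentyl in place of pyridin-2-yl settles no direction beyond the scatter. A non-aromatic carbon ring on this nitrogen now joins phenyl at the same limit: the limit of > 10000 nM in this assay, at which 2 of the 4 values shown sit.

Going by these compounds, what a longer chain, an amine or a carboxylic acid on this nitrogen would give remains open. Also open, on these data alone, is whether cyclopentyl on the fluoro-bearing core of compound 1 would give a number rather than a limit.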